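Heteroaryl variation on the shared core: step to compound 4

The source may hold more compounds than are shown below. What is called first, only, known or untested is meant among the compounds shown, and "the series" means these compounds.

Measured compounds:
- compound 1 `C[C@@H](O[C@H]1CN2C(=O)C=C(c3ccncc3)CC2[C@@H]1c1ccc(F)cc1)c1cc(C(F)(F)F)cc(C(F)(F)F)c1` gives 8.1 nM
- compound 2 `COc1cc(C2=CC(=O)N3C[C@H](O[C@H](C)c4cc(C(F)(F)F)cc(C(F)(F)F)c4)[C@@H](c4ccc(F)cc4)C3C2)ccn1` gives 44 nM
- compound 3 `C[C@@H](O[C@H]1CN2C(=O)C=C(c3ccc[n+]([O-])c3)CC2[C@@H]1c1ccc(F)cc1)c1cc(C(F)(F)F)cc(C(F)(F)F)c1` gives 2.3 nM

All three were run in an assay on CHO cells for displacement of a labelled ligand from Substance-P receptor (Homo sapiens), in the presence of a further agent that is not named here; on this read-out higher numbers stand for weaker inhibition and lower numbers for stronger inhibition. Compound 3 stands lowest of the three numbers; its nearest neighbour is compound 1 and its furthest compound 2, both gaps beyond the scatter.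

Compound 4 `CCc1noc(C2=CC(=O)N3C[C@H](O[C@H](C)c4cc(C(F)(F)F)cc(C(F)(F)F)c4)[C@@H](c4ccc(F)cc4)C3C2)n1` is not yet measured. It differs from compound 3 in one place: a group of 7 heavy atoms (4 carbon, 2 nitrogen, 1 oxygen; one five-membered aromatic ring with 3 hetero atoms) in place of a group of 7 heavy atoms (5 carbon, 1 nitrogen, 1 oxygen; one six-membered aromatic ring with 1 hetero atom), on a double-bonded ring carbon.

Going by the values given here, the steps that bear on this change are those that vary the same group on the same ring carbon. Moving from the parent ring to its methoxy analogue gave a 5.4-fold higher number from compound 1 to compound 2 (0.73 log units; beyond the scatter); the oxide gave a 3.5-fold lower number from compound 1 to compound 3 (0.55 log units; beyond the scatter) and a 19-fold lower number from compound 2 to compound 3 (1.28 log units; beyond the scatter). None of these involves a five-membered ring, so the direction for compound 4 is not fixed by the data. Since compound 3 is the lowest number and this position has so far moved numbers in both directions, a return toward the higher numbers is expected. Compound 4 is estimated at 10 nM with a range of 2.5 nM to 40 nM, which would mean an expected step of a 4.3-fold higher number from compound 3 to compound 4 (0.64 log units; beyond the scatter).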

Compound 4, half-maximal inhibitory concentration: 27 nM
Compound 4: the middle estimate sits 2.7-fold (0.43 log units) below what was measured; the range from low to high includes it.
By their numbers in this assay, from the lowest: compound 3; then compound 1; then compounds 4 and 2 (each within the scatter of the next).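

In this assay the first five-membered ring at this double-bonded ring carbon, 3-ethyl-1,2,4-oxadiazol-5-yl, gives a 12-fold higher number from compound 3 to compound 4 (1.07 log units; beyond the scatter) and a 3.3-fold higher number from compound 1 to compound 4 (0.52 log units; beyond the scatter) and so does not keep the numbers of either of the two lowest compounds. Against 2-methoxypyridin-4-yl it gives a 1.6-fold lower number from compound 2 to compound 4 (0.21 log units; within the scatter) and cannot be told apart from that group, which shows that a six-membered aromatic ring is not needed at this carbon to reach the level of compound 2. Nothing in the data gives a reason for these steps.

On these data alone, how a methyl group or a longer chain in place of the ethyl on the five-membered ring would shift the number remains open. So does the effect of an amine on that ring, or of an imidazole in place of the whole oxadiazole.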